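Indoline in Place of Piperidine Without a Cytotoxicity Signal

The source may hold more compounds than are shown below. What is called first, only, known or untested is meant among the compounds shown, and "the series" means these compounds.

Three close relatives were tested in an ADME assay on HepG2 cells (Homo sapiens) for cytotoxicity, read by CellTiter-Glo and ATP content, with a stated time of 72 h; on this read-out higher numbers stand for an effect only at larger amounts of compound and lower numbers for an effect already at smaller amounts. Compound 1 `CS(=O)(=O)c1ccc(C(=O)N2CCC(C(=O)N(Cc3ccccc3)c3ccccc3)CC2)cc1[N+](=O)[O-]` gives > 27000 nM in this assay, a figure that is a limit of the assay rather than a number. Compound 2 `CS(=O)(=O)c1ccc(C(=O)N2CCC(C(=O)N3CCc4ccccc43)CC2)cc1[N+](=O)[O-]` likewise gives > 27000 nM in this assay, again a limit. Compound 3 `CS(=O)(=O)c1ccc(C(=O)NCCC(=O)N2CCCCC2)cc1[N+](=O)[O-]` gives > 27000 nM in this assay, also a limit and not a measured number. Among the measured compounds shown here, compound 3 therefore stands where the others stand: all values sit at the limit of > 27000 nM in this assay, at which 3 of the 3 values shown sit, and no compound among the three shows a measurable effect on ATP content within the tested range.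

Compound 4 `CS(=O)(=O)c1ccc(C(=O)NCCC(=O)N2CCc3ccccc32)cc1[N+](=O)[O-]` differs from compound 3 in a single place: 2,3-dihydro-1H-indol-1-yl in place of piperidin-1-yl on a carbonyl carbon. Compound 2 carries the same 2,3-dihydro-1H-indol-1-yl group on a related core and gives a limit in this assay, while compound 1 with a different amide substituent gives the same limit.

With every value at the limit, the step from compound 3 to compound 4 is expected to be a number no higher from compound 3 to compound 4 (the limit leaves the size open), that is no change beyond the scatter. Compound 4 is therefore estimated at 27000 nM in this assay, with a range from 13500 nM to 54000 nM, and most likely another limit.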

Compound 4, half-maximal effective concentration: > 27000 nM
Compound 4 gave a limit, no number (the forecaster's own chance of this, stated with the estimate: 85%); the middle value sits exactly at the limit.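

In this assay compound 4 gives > 27000 nM, a limit and not a number. Compound 3 also stands at a limit, so no step can be read from compound 3 to compound 4. All values shown sit at one limit: the limit of > 27000 nM in this assay, at which 4 of the 4 values shown sit.

The compounds shown leave open at what concentration, if any, each would lower ATP content.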